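A few compounds are considered here, and "the series" means these few. Any claim that something is new, unique, unknown or untested is made for them only; others in the source may bear on it.

Of the compounds shown here, three have numbers so far. In an in vitro functional assay on HEK293 cells for antagonist activity at metabotropic glutamate receptor 6 (Homo sapiens), read by reporter gene assay, luminescence and calcium flux, tested at 10 uM (a higher number here means a weaker inhibitor, a lower number a stronger inhibitor), compound 1 `CCOC(=O)c1c(N)sc(-c2ccccc2)c1-c1ccccc1` gives 4500 nM, and compound 2 `COC(=O)c1c(N)sc(-c2ccccc2)c1C` gives 4100 nM; these two figures lie within the scatter of each other. Compound 3 `CCOC(=O)c1c(N=NN2CCOCC2)sc(-c2ccccc2)c1C` gives 54000 nM in this assay, the highest of the three numbers and beyond the scatter above both compound 1 and compound 2. Compound 1 and compound 2 both carry an amino group on the ring carbon next to the ring sulfur, where compound 3 carries a larger group.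

Compound 4 `CCOC(=O)c1c(Cl)sc(-c2ccccc2)c1C` has not yet been measured in this assay. From compound 3 to compound 4 the change is one chlorine atom in place of a group of 8 heavy atoms (4 carbon, 3 nitrogen, 1 oxygen; one six-membered non-aromatic ring with 2 hetero atoms), on an aromatic carbon. Within the data shown here, no measured pair differs in just this way, so no step of this kind is available. Among the measured compounds shown here, compound 1 and compound 2, which lack the larger group, sit well below compound 3, so a return toward their range is the reasonable expectation; chloro is not amino, however, and no member with chloro at this carbon has a number.

In this assay a fall beyond the scatter is expected, a 5.4-fold lower number from compound 3 to compound 4 (0.73 log units; beyond the scatter). Compound 4 is expected to give 10000 nM, with a range from 3000 nM to 40000 nM.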

Compound 4, half-maximal inhibitory concentration: 10000 nM
Compound 4: middle estimate and measured number agree at the digits printed; the measured number falls inside the stated range.
By their numbers in this assay, from the lowest: compounds 2 and 1 (each within the scatter of the next); then compound 4; then compound 3.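

Among these compounds, with a 5.4-fold lower number from compound 3 to compound 4 (0.73 log units; beyond the scatter) in this assay, this is the first step that changes only the aromatic carbon next to the ring sulfur, with the ethoxycarbonyl, methyl and phenyl groups held constant, and it shows that the group on this carbon alone moves the number beyond the scatter. The change is modest, and the chlorine atom that enters brings no hydrogen-bond acceptor, whereas the group of 8 heavy atoms that leaves carries 3, so a lower number at this carbon does not require any acceptor there. No measurement here bears on why the number falls.

Compound 4 differs from compound 1 and from compound 2 in more than one place, so steps from it to either cannot be read, and chloro cannot yet be set against amino on a matched core. This single step also cannot separate the size of the leaving group from its six-membered ring or its double bond; a bromine atom, a methoxy group or a dimethylamino group on the same carbon would begin to divide these.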